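The source may report more compounds than this note shows. Statements on the series, on what has been measured and on what is new or still open speak of the compounds shown alone.

Compound 1 `Oc1ccc(-c2cc(-c3ccncc3)nc(-c3ccc(Cl)cc3)c2)cc1` carries a pyridin-4-yl group and a 4-chlorophenyl group on its shared core, with a 4-hydroxyphenyl group completing the set, and in a functional assay on DU-145 cells (Homo sapiens) for cytotoxicity, read by CCK-8 assay and cell counting, with a stated time of 2 days (on this read-out lower numbers stand for stronger inhibition and higher numbers for weaker inhibition), compound 1 gives "not determined" (no result reported). There is thus no single number to place it by. Among the measured compounds shown here, a close relative, compound 2 `Oc1cccc(-c2cc(-c3ccncc3)nc(-c3ccc(Cl)cc3)c2)c1`, has been measured: in this assay compound 2 gives 2510 nM, which is the only firm number available so far.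

The step under study leads to compound 3 `Oc1ccc(-c2cc(-c3ccc(Cl)cc3)nc(-c3cccs3)c2)cc1`. The change is thiophen-2-yl in place of pyridin-4-yl on an aromatic carbon, and it sits next to the ring nitrogen of the shared core, with the 4-chlorophenyl and 4-hydroxyphenyl groups left untouched. For the measured compounds named here, because compound 1 itself has no value, no measured step can be drawn from it, and nothing shows which way this swap should push the read-out in this assay. The most defensible expectation is a change of no more than the usual scatter, in either direction, anchored loosely on what compound 2 shows. Compound 3 is therefore expected to give about 3000 nM in this assay, with an estimated range from 800 nM to 12000 nM.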

Compound 3, half-maximal inhibitory concentration: 7660 nM
The estimate for compound 3 lay 2.6-fold (0.41 log units) below the measured number; low and high end bracket the measured number.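

Among the compounds shown here, compound 3 differs from compound 1 in one place, but in this assay compound 1 gives "not determined" (no result reported), so no step between them can be read. The compounds shown leave open how thiophen-2-yl in place of pyridin-4-yl shifts the read-out. No measured evidence bears on the value of compound 3.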